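Nitro on the aniline ring of the shared core

This account rests on a few compounds, and the source may have more. Where it says the series, first, only, none or still open, it means among the compounds named here.

Compound 1 `O=S(=O)(Nc1ccccc1)c1ccccc1` carries the shared core without further substitution and gives 9.1 in an ADME assay. Among the three measured compounds it stands highest: compound 3 `O=S(=O)(Nc1ccccc1)c1ccc(Br)cc1` gives 8.5, and compound 2 `O=S(=O)(Nc1ccccc1)c1ccc(Cl)cc1` gives 8.47. The step of a number 0.60 log units lower from compound 1 to compound 3 (beyond the scatter) and the step of a number 0.63 log units lower from compound 1 to compound 2 (beyond the scatter) are both beyond the scatter, while the step of a number 0.03 log units higher from compound 2 to compound 3 (within the scatter) is within it.

Compound 4 `O=[N+]([O-])c1cccc(NS(=O)(=O)c2ccccc2)c1` differs from compound 1 by nitro in place of hydrogen on an aromatic carbon. Going by the values given here, no measured pair shows a nitro group, and none shows a change on this ring of the core; the only steps available are the two halogen steps on the other ring, each a modest fall in this assay. On that basis a downward step in this assay is expected for compound 4, and since the entering group and its place are both untested the estimate is kept wide. The expected step is a number 1.20 log units lower from compound 1 to compound 4 (beyond the scatter), giving an estimate for compound 4 of 7.9 with a range of 7.3 to 8.5.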

Compound 4, acid dissociation constant: 7.93
The estimate for compound 4 lay 0.03 log units below the measured number, within the range that was stated.
By their numbers in this assay, from the lowest: compound 4; then compounds 2 and 3 (each within the scatter of the next); then compound 1.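

In this assay nitro in place of hydrogen on an aromatic carbon, meta to a large group, gives a number 1.17 log units lower from compound 1 to compound 4 (beyond the scatter) and this step counts as large, so a change on this ring of the shared core does move the number. The halogen steps on the other ring (a number 0.63 log units lower from compound 1 to compound 2 (beyond the scatter) and a number 0.60 log units lower from compound 1 to compound 3 (beyond the scatter)) count as modest, but they differ from this step in both the entering group and its place, so group and position cannot be separated here. Nothing measured on these compounds accounts for the size of the step.

Still open, from the compounds shown here alone, is how nitro behaves on the other ring, or at other places on this one. Also open, going by these compounds, is whether chloro, bromo, an amine or a carboxylic acid at this same place would shift the number in the same direction.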